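A Change of Aryl Substituent and Expected Tolerance

The source may report more compounds than this note shows. Statements on the series, on what has been measured and on what is new or still open speak of the compounds shown alone.

Compound 1 `Cc1cc(F)ccc1Cc1c(C)c2ccc(OCC(O)CN3CCC(C(N)=O)CC3)cc2oc1=O` was tested in an ADME assay on A549 cells (Homo sapiens) for cytotoxicity, read by CellTiter-Glo; a higher number here means that more compound is tolerated, a lower number that less compound is tolerated. In this assay compound 1 gives > 100000 nM, which is a limit of the assay rather than a number. Among the values shown, compound 1 stands at the limit of > 100000 nM in this assay, at which 1 of the 2 values shown sits. In this assay compound 2 `CC(=O)C1CCN(CC(O)COc2ccc3c(C)c(Cc4cccc([N+](=O)[O-])c4)c(=O)oc3c2)CC1` gives 90500 nM. Compound 3 `COC(=O)c1ccc(Cc2c(C)c3ccc(OCC(O)CN4CCC(C(N)=O)CC4)cc3oc2=O)cc1` differs from compound 1 by 4-(methoxycarbonyl)phenyl in place of 4-fluoro-2-methylphenyl on a saturated chain carbon bound to an aromatic carbon. Among the measured compounds shown here, no measured step connects these two compounds, and for this change no step beyond the usual scatter is expected in either direction. Compound 3 is therefore estimated at 100000 nM, within 50000 nM to 200000 nM. The expected step is a number no higher from compound 1 to compound 3 (the limit leaves the size open).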

Compound 3, half-maximal cytotoxic concentration: > 100000 nM
Compound 3 was reported as a limit; the forecaster's own chance of this, stated with the estimate: 50%; the middle value lies on the limit itself.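

Among the compounds shown here, compound 1 and compound 3 both stand at a limit of this assay, not at a number, so no step between them can be read: the limit of > 100000 nM in this assay, at which 2 of the 3 values shown sit. As far as these compounds go, whether 4-(methoxycarbonyl)phenyl in place of 4-fluoro-2-methylphenyl makes any difference in tolerance remains open.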